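The source may hold more compounds than are shown below. What is called first, only, known or untested is meant among the compounds shown, and "the series" means these compounds.

Working notes on the hydrazone series, scored in a functional assay on U-87MG ATCC cells (Homo sapiens) for cytotoxicity, read by MTT assay, with a stated time of 72 h; on this read-out lower numbers stand for stronger inhibition and higher numbers for weaker inhibition.

Measured so far:
compound 1, `CN(C)CCn1cnnc1-c1cc(Oc2ccc(NC(=O)N/N=C/c3cccc(Cl)c3Cl)cc2F)ccn1`, 13200 nM
compound 2, `CN(C)CCn1cnnc1-c1cc(Oc2ccc(NC(=O)N/N=C/c3ccc(O)c(O)c3)cc2F)ccn1`, a limit of the assay, > 100000 nM
compound 3, `CN(C)CCn1cnnc1-c1cc(Oc2ccc(NC(=O)N/N=C/c3c(O)ccc4ccccc34)cc2F)ccn1`, 620 nM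

Compound 3 gives the lowest of the two numbers; the nearest number is compound 1, with a 21-fold lower number from compound 1 to compound 3 (1.33 log units; beyond the scatter). Compound 2 returned only a limit, (the limit of > 100000 nM in this assay, at which 1 of the 3 values shown sits), so an at least 160-fold lower number from compound 2 to compound 3 (2.20 log units; beyond the scatter) and an at least 7.5-fold higher number from compound 1 to compound 2 (0.87 log units; beyond the scatter) are bounds rather than exact sizes.

Next up is compound 4, `Cc1cc(/C=N/NC(=O)Nc2ccc(Oc3ccnc(-c4nncn4CCN(C)C)c3)c(F)c2)cc(C)c1O`. The change from compound 3: 4-hydroxy-3,5-dimethylphenyl in place of 2-hydroxynaphthalen-1-yl on a carbon with a double bond to nitrogen.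

Going by the values given here, two measured steps bear on this change, since both end at compound 3 and both replace a single-ring aryl with the 2-hydroxynaphthalen-1-yl: a 21-fold lower number from compound 1 to compound 3 (1.33 log units; beyond the scatter) and an at least 160-fold lower number from compound 2 to compound 3 (2.20 log units; beyond the scatter). Going the other way, back to a single six-membered ring carrying a hydroxyl, the expectation is a rise in the number beyond the scatter. The 4-hydroxy-3,5-dimethylphenyl is not the 3,4-dihydroxyphenyl of compound 2, so a result short of that limit seems the more likely outcome, nearer the region of compound 1. The step expected is a 9.7-fold higher number from compound 3 to compound 4 (0.99 log units; beyond the scatter). Compound 4 is estimated at 6000 nM, within a range from 1500 nM to 30000 nM.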

Compound 4, half-maximal inhibitory concentration: 7710 nM
Estimate against measurement, compound 4: 1.3-fold (0.11 log units) below; measured number inside the range.
By their numbers in this assay, from the lowest: compound 3; then compounds 4 and 1 (each within the scatter of the next). At a limit, above all of these: compound 2.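

In this assay, the 4-hydroxy-3,5-dimethylphenyl on this carbon gives a 12-fold higher number from compound 3 to compound 4 (1.09 log units; beyond the scatter), so among the compounds shown, a hydroxyl on a single aromatic ring does not match the 2-hydroxynaphthalen-1-yl. Nor does a hydroxylated single ring place a compound at the weak end of the series, with an at least 12-fold lower number from compound 2 to compound 4 (1.11 log units; beyond the scatter), though this step is only a bound, as compound 2 stands at a limit of the assay: the limit of > 100000 nM in this assay, at which 1 of the 4 values shown sits. The 4-hydroxy-3,5-dimethylphenyl and the 2,3-dichlorophenyl cannot be separated, with a 1.7-fold lower number from compound 1 to compound 4 (0.23 log units; within the scatter), so two rather different single-ring groups give results that lie within the scatter of each other.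

The compounds shown do not settle whether the 2-hydroxynaphthalen-1-yl owes its standing to the second aromatic ring or to where its hydroxyl sits, a question that a naphthalen-1-yl without the hydroxyl and a 2-hydroxyphenyl would help to separate. From the compounds shown here alone, how this position responds to an amine or a carboxylic acid on the aromatic ring also remains open.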